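A few compounds are considered here, and "the series" means these few. Any claim that something is new, unique, unknown or untested is made for them only; others in the source may bear on it.

Working notes on the series in a functional assay on HEK293 cells for agonist activity at D(4) dopamine receptor (Homo sapiens), read by FLIPR; on this read-out higher numbers stand for larger maximal responses and lower numbers for smaller maximal responses. Compound 1 `O=C(CN1CCC(c2cccc[n+]2[O-])CC1)Nc1cccc(Cl)c1` gives 76% in this assay. Compound 2 `Cc1cccc(NC(=O)CN2CCC(c3ccccc3C#N)CC2)c1` gives 71% and compound 3 `Cc1cccc(C(=O)NCN2CCC(c3ccccn3)CC2)c1` gives 67%. The three numbers lie close together: the gap from compound 1 to compound 2 and the gap from compound 1 to compound 3 both fall within the usual scatter of repeated measurements, so no order among the three can be read from this assay.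

Compound 4 `Cc1cc(NC(=O)CN2CCC(c3cccc[n+]3[O-])CC2)ccc1F` has not been measured. It differs from compound 1 in one place: 4-fluoro-3-methylphenyl in place of 3-chlorophenyl on an amide-type nitrogen. Among the compounds with values here, no measured pair shows this change, so there is nothing in the data to set a direction for it. The expected step is a number 4 percentage points lower from compound 1 to compound 4 (within the scatter), that is, none beyond the scatter, resting only on the fact that all three measured compounds give numbers within the scatter of one another.

For compound 4 in this assay the estimate is 72%, with a range from 55% to 90%.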

Compound 4, largest response reached (reported as efficacy), in percent of the reference or control that the assay uses: 75%
Estimate against measurement, compound 4: 3 percentage points below; the range from low to high includes it.
By their numbers in this assay, from the lowest: compounds 3, 2, 4 and 1 (each within the scatter of the next).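

Within the data shown here, compounds 1 and 4 form the first measured pair that differs in one place. Among these compounds, on the amide-type nitrogen, 4-fluoro-3-methylphenyl in place of 3-chlorophenyl gives a number 1 percentage points lower from compound 1 to compound 4 (within the scatter) in this assay, so this change on the core of compound 1 leaves no step that can be told from the scatter. Nothing measured here gives a cause for this result or separates the parts of the change.

On these data alone, this single pair changes the chlorine, the fluorine and the methyl together, so what each contributes on its own stays open, as does whether the result would hold on the core of compound 2 or compound 3. Also open, as far as these compounds go, is whether an unsubstituted phenyl, a benzyl or a cyclohexyl on this nitrogen would keep the response within the scatter of compound 1.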